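Methoxy to methylsulfanyl on a urea-linked quinoline-free core

The source may hold more compounds than are shown below. What is called first, only, known or untested is meant among the compounds shown, and "the series" means these compounds.

Compound 1 has the structure `COc1ccc(NC(=O)Nc2cc(C)nc3ccccc23)cc1`. In an ADME assay on Raji cells (Homo sapiens) for cytotoxicity, with a stated time of 72 h (a higher number here means that more compound is needed for the effect, a lower number that less compound is needed), compound 1 gives > 25000 nM, which is a limit of the assay rather than a measured number. Two neighbouring compounds share this picture. Compound 2, `COc1ccc(NC(=O)Nc2cc(C)nc3ccccc23)cc1F`, carries a fluorine on the same ring; in this assay compound 2 gives > 25000 nM, again a limit. Compound 3, `Cc1cc(NC(=O)Nc2cc(F)ccc2F)c2ccccc2n1`, replaces that ring with a difluorinated one; in this assay compound 3 gives > 25000 nM, also a limit. Going by the values given here, the one step that connects two of these, a step that the two limits leave unreadable from compound 1 to compound 2, cannot be sized, since both ends sit at the limit, and the same holds for every value here: the limit of > 25000 nM in this assay, at which 3 of the 3 values shown sit.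

Compound 4, `CSc1ccc(NC(=O)Nc2cc(C)nc3ccccc23)cc1`, differs from compound 1 by methylsulfanyl in place of methoxy on an aromatic carbon. Among the compounds with values here, no measured step bears directly on this change. Only limits are available, so the evidence supports no expectation of a step in either direction beyond the scatter. Compound 4 is therefore expected to give about 30000 nM in this assay, somewhere between 12000 nM and 100000 nM, most likely reported as a limit again. This estimate means a step that the limit leaves unreadable from compound 1 to compound 4, expected to be essentially flat.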

Compound 4, half-maximal effective concentration: > 25000 nM
Compound 4: only a limit was reported; the forecaster's own chance of this, stated with the estimate: 80%; the middle value lies beyond the limit too.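

The swap of methoxy for methylsulfanyl between compound 1 and compound 4 gives no readable step, because all the compounds stop at the same point: the limit of > 25000 nM in this assay, at which 4 of the 4 values shown sit.

The compounds shown leave open how much of any of them is needed for the effect in this assay, and whether any change to the shared core would shift it.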